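A few compounds are considered here, and "the series" means these few. Any claim that something is new, unique, unknown or untested is made for them only; others in the source may bear on it.

In an ADME assay on the whole organism (plasma) for pharmacokinetics, with Canis familiaris (Canis lupus familiaris) as the target, at a dose of 0.6 mg/kg by the oral route (on this read-out higher numbers stand for higher exposure at the dose given and lower numbers for lower exposure), compound 1 (`Cc1ccc([C@H](C(=O)N(C)C)N2C(=O)[C@@H](C3Cc4ccccc4C3)NC(=O)[C@H]2CC(C)C)cn1`) gives 454 ng.h/mL and compound 2 (`CCC(CC)[C@@H]1C(=O)N[C@H](C2Cc3ccccc3C2)C(=O)N1[C@@H](C(=O)N(C)C)c1ccc(C)nc1`) gives 255 ng.h/mL, so the two lie within the scatter of each other. Compound 3 (`COc1ccc([C@H](C(=O)N(C)C)N2C(=O)[C@@H](C3Cc4ccccc4C3)NC(=O)[C@H]2CC(C)C)cn1`) differs from compound 1 in one place: methoxy in place of methyl on an aromatic carbon. Among the measured compounds shown here, the only measured step, a 1.8-fold lower number from compound 1 to compound 2 (0.25 log units; within the scatter), lies on a saturated ring carbon and stays within the scatter, and no measured step touches this aromatic carbon. No change beyond the scatter is therefore expected, and the data give no direction. The expected step is a 1.1-fold lower number from compound 1 to compound 3 (0.05 log units; within the scatter). Compound 3 is estimated at 400 ng.h/mL, with an expected range from 150 ng.h/mL to 1050 ng.h/mL.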

Compound 3, area under the concentration-time curve: 158 ng.h/mL
Estimate against measurement, compound 3: 2.5-fold (0.40 log units) above, within the range that was stated.
By their numbers in this assay, from the lowest: compounds 3, 2 and 1 (each within the scatter of the next, the first and the last beyond it).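

In this assay, methoxy in place of methyl on the aromatic carbon next to the ring nitrogen gives a 2.9-fold lower number from compound 1 to compound 3 (0.46 log units; beyond the scatter) and is the only single change shown that lies beyond the scatter. This position is therefore not indifferent to the group it carries, at least for this one exchange. No evidence here bears on the reason for the drop. Open, from the compounds shown here alone, is how an ethoxy group, a chlorine atom or an amine on this carbon would compare with methyl, and whether methoxy gives a similar step with the pentan-3-yl group of compound 2.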